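Swapping the Isoquinoline for a Methylpyrazine

The source may report more compounds than this note shows. Statements on the series, on what has been measured and on what is new or still open speak of the compounds shown alone.

Compound 1 `O=C(N1CCC(c2ccccc2)CC1)N(c1nccc2ccccc12)[C@@H]1CCCNC1` and compound 2 `Cc1ccc2c(N3CCN(C(=O)N(c4nccc5ccccc45)[C@@H]4CCCNC4)CC3)noc2c1` share a core and were both tested in an ADME assay on cells (Bone marrow cell, Rattus norvegicus) for cytotoxicity, with a stated time of 72 h; a higher number here means a weaker inhibitor, a lower number a stronger inhibitor. Compound 1 gives 12700 nM, the lowest of the two numbers, while compound 2 gives 31100 nM, a gap beyond the scatter. Compound 3 `Cc1nccnc1N(C(=O)N1CCC(c2ccccc2)CC1)[C@@H]1CCCNC1` is not yet measured; it differs from compound 1 by 3-methylpyrazin-2-yl in place of isoquinolin-1-yl on an amide-type nitrogen. Among the measured compounds shown here, no measured pair shows this change, so its size is open. For compound 3 a step of a 2.0-fold higher number from compound 1 to compound 3 (0.29 log units; within the scatter) toward a modestly higher number is expected. Compound 3 is therefore estimated at 25000 nM, with a range from 8000 nM to 80000 nM.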

Compound 3, half-maximal inhibitory concentration: > 100000 nM
Compound 3 gave a limit, no number; the forecaster's own chance of this, stated with the estimate: 20%; middle value at least 4.0-fold (0.60 log units) away from the limit.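

Putting 3-methylpyrazin-2-yl in place of isoquinolin-1-yl on the amide-type nitrogen gives an at least 7.8-fold higher number from compound 1 to compound 3 (0.89 log units; beyond the scatter) in this assay, so the group at this position clearly matters for this read-out. The result for compound 3 is a limit of the assay and not a number, so the step has a lower bound but no known full size: the limit of > 100000 nM in this assay, at which 1 of the 3 values shown sits.

The change removes one aromatic ring and adds a methyl together, and the compounds shown do not separate the two. They also leave open how a pyrazine carrying an amine in place of the methyl would behave.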